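Swapping the Charged Head Group on a Seven-Carbon Linker

The compounds below may be only part of what the source reports. "The series", "measured", "known", "first", "only" and "open" are said of these compounds alone.

Compound 1 `Cc1cc(-n2cc(C(=O)Nc3cc(F)cc(F)c3)c(=O)c3ccc(N(C)C)nc32)ccc1OCCCCCCC[N+]12CCN(CC1)CC2` carries a charged head at the end of a saturated chain that runs from an oxygen on an aromatic ring. In an assay on LX2 cells for inhibition of COL1A1 promoter (Homo sapiens), read by a luciferase reporter, with a stated time of 24 h, tested at 20 uM (a higher number here means a stronger effect of the compound at the concentration tested, a lower number a weaker effect), compound 1 gives 10.6%. Its companion, compound 2 `Cc1ccc(-n2cc(C(=O)Nc3cc(F)cc(F)c3)c(=O)c3ccc(N(C)C)nc32)cc1OCCCCCCC[N+]12CCN(CC1)CC2`, is built on the same core with the same chain and the same head group, and in this assay compound 2 gives 5.07%. Compound 1 has the higher of the two numbers, but the gap between them lies within the scatter of repeated measurements, so the two cannot be told apart.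

Compound 3 `Cc1cc(-n2cc(C(=O)Nc3cc(F)cc(F)c3)c(=O)c3ccc(N(C)C)nc32)ccc1OCCCCCCC[N+]1(C)CCN(C)CC1` has not yet been measured. It differs from compound 1 at one place: a group of 8 heavy atoms (6 carbon, 2 nitrogen; one six-membered non-aromatic ring with 2 hetero atoms) in place of a group of 8 heavy atoms (6 carbon, 2 nitrogen; 2 six-membered non-aromatic rings with 2 hetero atoms each), on a saturated chain carbon, seven bonds along the chain from an oxygen on an aromatic ring. Within the data shown here, no measured pair in this set shows what such an exchange of one charged head for another does, so there is no step to draw on. With both measured compounds sitting at low inhibition, the expected step is none beyond the scatter, a number 1.6 percentage points lower from compound 1 to compound 3 (within the scatter) in this assay. For compound 3 the expected value in this assay is 9%, within a range from -6% to 24%.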

Compound 3, a percentage reported as inhibition, at one concentration (the size of the read-out at that concentration, not a potency): 16.2%
Estimate against measurement, compound 3: 7.2 percentage points below; the measured number falls inside the stated range.
By their numbers in this assay, from the lowest: compounds 2, 1 and 3 (each within the scatter of the next, the first and the last beyond it).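

Among these compounds, the exchange on a saturated chain carbon, seven bonds along the chain from an oxygen on an aromatic ring, is the first change in this set made at one place, and in this assay it gives a number 5.6 percentage points higher from compound 1 to compound 3 (within the scatter). At this position, then, the group with one six-membered non-aromatic ring cannot be told apart from the group with 2 such rings, while both groups have 8 heavy atoms and a net charge of +1, so this measurement shows no effect of the exchange beyond the usual scatter. Nothing available here offers an explanation for this result.

On these data alone, whether a head without a ring, such as trimethylammonium, or a shorter or longer chain carrying the head of compound 3 would move the read-out beyond the scatter remains open. Also open is whether the same exchange, made on compound 2, would give a step of similar size, since the one step shown here comes from a single pair on the core of compound 1.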